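Replacing the Urea End Group with a Benzamide

This account rests on a few compounds, and the source may have more. Where it says the series, first, only, none or still open, it means among the compounds named here.

Compound 1 `COc1cc(-c2nn(-c3cccc(NC(=O)Nc4ccc(Cl)c(Cl)c4)c3)cc2-c2ccncc2)ccc1Cl` in a functional assay on SN12C cells (Homo sapiens) for inhibition, read by sulforhodamine B assay, with a stated time of 48 h (a higher number here means that more compound is tolerated, a lower number that less compound is tolerated), gives > 50000 nM.
Compound 2 `COc1cc(-c2nn(-c3cccc(NC(=O)Nc4cccc(C(F)(F)F)c4)c3)cc2-c2ccncc2)ccc1Cl` in this assay gives > 50000 nM.
Compound 3 `COc1cc(-c2nn(-c3cccc(NC(=O)Nc4ccc(Cl)c(C(F)(F)F)c4)c3)cc2-c2ccncc2)ccc1Cl` in this assay gives > 32500 nM.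

Each of these values is a limit of the assay rather than a measured number. Compound 3 stands at the limit of > 32500 nM in this assay, at which 1 of the 3 values shown sits, while the other two compounds sit at the limit of > 50000 nM in this assay, at which 2 of the 3 values shown sit. All three compounds share the same core and differ only in the substituents on the outer ring of the urea.

The steps between them, a step that the two limits leave unreadable from compound 1 to compound 2, a step that the two limits leave unreadable from compound 1 to compound 3 and a step that the two limits leave unreadable from compound 2 to compound 3, cannot be read in size or direction, since every value involved is a limit.

Compound 4 `COc1cc(-c2nn(-c3cccc(NC(=O)c4ccccc4)c3)cc2-c2ccncc2)ccc1Cl` removes the urea pattern entirely: phenyl in place of (4-chloro-3-(trifluoromethyl)phenyl)amino on a carbonyl carbon. Within the data shown here, no measured step speaks to this change, and the three unreadable steps give no direction. Compound 4 is therefore expected to behave like its neighbours, with a step that the limit leaves unreadable from compound 3 to compound 4 that is not readable against the limits. The estimate for compound 4 in this assay is 50000 nM, with a range from 15000 nM to 100000 nM, and most likely only a limit will be reported.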

Compound 4, concentration lethal to 50% of the cells: > 100000 nM
Compound 4: a limit, no number; the forecaster's own chance of this, stated with the estimate: 75%; middle value at least 2.0-fold (0.30 log units) from the limit.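

In this assay compound 4 gives > 100000 nM, which is a limit of the assay and not a number. Its steps from compound 1, compound 2 and compound 3 therefore cannot be read in size or direction. The compounds shown leave open whether replacing the urea end group with a benzamide shifts the value in this assay at all.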